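One Shared Core, a Fourth Variant Still Unmeasured

The source may report more compounds than this note shows. Statements on the series, on what has been measured and on what is new or still open speak of the compounds shown alone.

Three compounds have been measured in a functional assay on PCO3 cells (Homo sapiens) for cytotoxicity, read by sulforhodamine B assay; on this read-out lower numbers stand for stronger inhibition of growth and higher numbers for weaker inhibition of growth:

Compound 1 `CC1=CC[C@@H]([C@@](C)(O)CCCC(C)(C)NC(=S)N/N=C\c2ccc(C)cc2)CC1` gives 6750 nM.
Compound 2 `COc1ccc(/C=N\NC(=S)NC(C)(C)CCC[C@](C)(O)[C@@H]2CC=C(C)CC2)cc1` gives 7660 nM.
Compound 3 `CC1=CC[C@@H]([C@@](C)(O)CCCC(C)(C)NC(=S)N/N=C\c2ccc(O)cc2)CC1` gives 6230 nM.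

Compound 1 stands second highest of these three numbers, but every step among them is small: a 1.1-fold higher number from compound 1 to compound 2 (0.05 log units; within the scatter), a 1.1-fold lower number from compound 1 to compound 3 (0.03 log units; within the scatter) and a 1.2-fold lower number from compound 2 to compound 3 (0.09 log units; within the scatter) all sit within the scatter. Compound 4 `CC1=CC[C@@H]([C@@](C)(O)CCCC(C)(C)NC(=S)N/N=C\c2cccc(Cl)c2)CC1` differs from compound 1 by 3-chlorophenyl in place of 4-methylphenyl on a carbon with a double bond to nitrogen. Within the data shown here, no measured step swaps the whole ring in this way; the three known steps only exchange one group on that ring for another, and each left the number essentially unchanged. The step is therefore expected to stay within the scatter, a 1.0-fold higher number from compound 1 to compound 4 (0.00 log units; within the scatter). Compound 4 is estimated at 6800 nM, within a range of 3200 nM to 14500 nM.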

Compound 4, concentration for 50% growth inhibition: 11300 nM
Compound 4: the middle estimate sits 1.7-fold (0.22 log units) below what was measured; measured number inside the range.
By their numbers in this assay, from the lowest: compounds 3, 1, 2 and 4 (each within the scatter of the next).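

Even replacing the whole ring with 3-chlorophenyl on the carbon with a double bond to nitrogen stays within the scatter in this assay, whether 4-methylphenyl leaves (a 1.7-fold higher number from compound 1 to compound 4 (0.22 log units; within the scatter)), 4-hydroxyphenyl leaves (a 1.8-fold higher number from compound 3 to compound 4 (0.26 log units; within the scatter)) or 4-methoxyphenyl leaves (a 1.5-fold higher number from compound 2 to compound 4 (0.17 log units; within the scatter)). No step among these four compounds therefore lies beyond the scatter, even with chlorine on the ring. Nothing available here explains these numbers.

As far as these compounds go, whether an amine or a carboxylic acid on the ring, or a cyclohexyl group in its place, would move the number beyond the scatter remains open.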